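From Isopropoxy to a Methylimidazolyl Group on a Shared Core

The source may hold more compounds than are shown below. What is called first, only, known or untested is meant among the compounds shown, and "the series" means these compounds.

Of the compounds shown here, three built on one shared core have been measured in a functional assay for inhibition of sodium/hydrogen exchanger (Oryctolagus cuniculus); on this read-out higher numbers stand for weaker inhibition and lower numbers for stronger inhibition. Compound 1 `Cc1cc(Br)c(S(C)(=O)=O)cc1C(=O)N=C(N)N` gives 12 nM, compound 2 `Cc1cc(-c2ccc(Cl)cc2Cl)c(S(C)(=O)=O)cc1C(=O)N=C(N)N` gives 42 nM, and compound 3 `Cc1cc(OC(C)C)c(S(C)(=O)=O)cc1C(=O)N=C(N)N` gives 19 nM. On these numbers compound 3 stands second highest: it lies within the scatter of compound 1, as a 1.6-fold higher number from compound 1 to compound 3 (0.20 log units; within the scatter) shows, whereas the number moves beyond the scatter in the step of a 2.2-fold lower number from compound 2 to compound 3 (0.34 log units; beyond the scatter).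

Compound 4 `Cc1cc(-n2ccnc2C)c(S(C)(=O)=O)cc1C(=O)N=C(N)N` has not yet been measured. It differs from compound 3 in one place: 2-methyl-1H-imidazol-1-yl in place of isopropoxy on an aromatic carbon.

The measured step that bears most on this change is a 3.5-fold higher number from compound 1 to compound 2 (0.54 log units; beyond the scatter), the one case in which an aromatic ring entered on that aromatic carbon, and it moved the number beyond the scatter. The group entering in compound 4 is a five-membered aromatic ring rather than the 2,4-dichlorophenyl of compound 2, so the author expects a rise of about the same order or less, near the edge of the scatter. The estimate for compound 4 is 30 nM, with a range from 10 nM to 90 nM, which corresponds to an expected 1.6-fold higher number from compound 3 to compound 4 (0.20 log units; within the scatter).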

Compound 4, half-maximal inhibitory concentration: 29 nM
Compound 4: the middle estimate sits 1.0-fold (0.01 log units) above what was measured; low and high end bracket the measured number.
By their numbers in this assay, from the lowest: compounds 1, 3, 4 and 2 (each within the scatter of the next, the first and the last beyond it).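

Compound 4 is the only one shown with a five-membered aromatic ring on this aromatic carbon, and in this assay this ring cannot be told apart from isopropoxy, with a 1.5-fold higher number from compound 3 to compound 4 (0.18 log units; within the scatter) inside the scatter. Nor can it be told apart from the 2,4-dichlorophenyl group, as a 1.4-fold lower number from compound 2 to compound 4 (0.16 log units; within the scatter) shows, whereas the step from bromo, a 2.4-fold higher number from compound 1 to compound 4 (0.38 log units; beyond the scatter), goes beyond the scatter, as the step to 2,4-dichlorophenyl had done. No measurement is available that would explain these steps.

As far as these compounds go, it remains open whether the methyl group on the new ring matters, which the unsubstituted imidazol-1-yl group would test. Also open, from the compounds shown here alone, is whether an amine, a carboxylic acid or a longer alkoxy chain on this aromatic carbon would stay in the same range of numbers.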